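From phenyl to 2,3-dimethylphenyl on a sulfonamide nitrogen

The source may report more compounds than this note shows. Statements on the series, on what has been measured and on what is new or still open speak of the compounds shown alone.

- compound 1 `Cc1cccc(NS(=O)(=O)c2ccc(N3CCNC3=O)cc2)c1`: 110 nM
- compound 2 `O=C1NCCN1c1ccc(S(=O)(=O)Nc2ccccc2)cc1`: 280 nM
- compound 3 `O=C1NCCN1c1ccc(S(=O)(=O)Nc2ccc(OC(F)F)cc2)cc1`: 650 nM

Among these three compounds, measured in a functional assay on HT-29 cells (Homo sapiens) for antiproliferative activity, read by sulforhodamine B assay, with a stated time of 48 h (on this read-out lower numbers stand for stronger inhibition and higher numbers for weaker inhibition), compound 2 stands in the middle at 280 nM, with compound 1 giving a lower number and compound 3 a higher one. The next compound, compound 4 `Cc1cccc(NS(=O)(=O)c2ccc(N3CCNC3=O)cc2)c1C`, has not yet been measured. It differs from compound 2 on the sulfonamide nitrogen: 2,3-dimethylphenyl in place of phenyl on a sulfonamide nitrogen. In short, 2,3-dimethylphenyl stands in place of phenyl.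

Among the compounds with values here, two measured steps bear on this change. The closer one is a 2.5-fold higher number from compound 1 to compound 2 (0.41 log units; beyond the scatter), with hydrogen in place of methyl on an aromatic carbon, so in this pair the methyl compound has the lower number. The other is a 2.3-fold higher number from compound 2 to compound 3 (0.37 log units; beyond the scatter), with difluoromethoxy in place of hydrogen on an aromatic carbon. Compound 3 thus goes against any rule that adding a group lowers the number. Within the data shown here, both steps are modest, and no measured compound carries two methyl groups. A modest move toward a lower number in this assay is therefore expected, resting mainly on a 2.5-fold higher number from compound 1 to compound 2 (0.41 log units; beyond the scatter). The expected change is a 2.3-fold lower number from compound 2 to compound 4 (0.37 log units; beyond the scatter). The estimate for compound 4 is 120 nM, with an expected range of 40 nM to 350 nM.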

Compound 4, half-maximal inhibitory concentration: 190 nM
The estimate for compound 4 lay 1.6-fold (0.20 log units) below the measured number; low and high end bracket the measured number.
By their numbers in this assay, from the lowest: compounds 1, 4 and 2 (each within the scatter of the next, the first and the last beyond it); then compound 3.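

In this assay, 2,3-dimethylphenyl in place of phenyl on the sulfonamide nitrogen gives a 1.5-fold lower number from compound 2 to compound 4 (0.17 log units; within the scatter), so this change produces no readable difference from the parent phenyl. The further methyl on the aromatic ring gives a 1.7-fold higher number from compound 1 to compound 4 (0.24 log units; within the scatter), which also cannot be read as a change, so a second methyl shows no measurable effect beyond the first. Compound 4 therefore cannot be separated from either of these two neighbours, although the two neighbours themselves are separated by a 2.5-fold higher number from compound 1 to compound 2 (0.41 log units; beyond the scatter), and nothing at hand accounts for these numbers.

The compounds shown leave open whether the aromatic ring on the sulfonamide nitrogen can take a group of another kind, such as an amine or a carboxylic acid, and how far the number would then move in this assay. They also leave open whether a longer chain, such as ethyl or propyl, would behave like methyl or would move the number in the direction seen with difluoromethoxy in compound 3.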